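Lengthening an Alkenoyl Ester Chain: Expected Potency

The source may hold more compounds than are shown below. What is called first, only, known or untested is meant among the compounds shown, and "the series" means these compounds.

Compound 1 `CC(=O)O[C@@]12CO[C@@H]1C[C@H](O)[C@@](C)(C(=O)[C@H](O)C1=C(C)C3C[C@@](O)([C@H](C)OC(=O)CCCCCCC(=O)N[C@@H](c4ccccc4)[C@@H](O)C(=O)O3)C1(C)C)C2` gives > 100000 nM in a functional assay on KB cells (Homo sapiens) for inhibition, with a stated time of 72 h (a higher number here means a weaker inhibitor, a lower number a stronger inhibitor), which is a limit of the assay and not a number.
Compound 2 `C=CCCC(=O)N[C@@H](c1ccccc1)[C@@H](O)C(=O)OC1C[C@@](O)([C@H](C)OC(=O)CCC=C)C(C)(C)C([C@@H](O)C(=O)[C@@]2(C)C[C@]3(OC(C)=O)CO[C@@H]3C[C@@H]2O)=C1C` gives 1600 nM in this assay.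
Compound 3 `C=CCCCCC(=O)N[C@@H](c1ccccc1)[C@@H](O)C(=O)OC1C[C@@](O)([C@H](C)OC(=O)CCCC=C)C(C)(C)C([C@@H](O)C(=O)[C@@]2(C)C[C@]3(OC(C)=O)CO[C@@H]3C[C@@H]2O)=C1C` gives 650 nM in this assay.

Compound 3 stands at the lowest of the two numbers measured; compound 2 sits beyond the scatter above it, while compound 1 shows only a limit (the limit of > 100000 nM in this assay, at which 1 of the 3 values shown sits). Compound 4 `C=CCCCCC(=O)N[C@@H](c1ccccc1)[C@@H](O)C(=O)OC1C[C@@](O)([C@H](C)OC(=O)CCCCC=C)C(C)(C)C([C@@H](O)C(=O)[C@@]2(C)C[C@]3(OC(C)=O)CO[C@@H]3C[C@@H]2O)=C1C` differs from compound 3 by allyl in place of vinyl on a saturated chain carbon, three bonds along the chain from a carbonyl carbon. Among the measured compounds shown here, no measured pair shows this change, so the expectation rests on the values alone: a small step in this assay is expected, if anything toward a lower number, but probably none beyond the scatter. Compound 4 is therefore expected near 500 nM, ranging from 200 nM to 1500 nM. The step of a 1.3-fold lower number from compound 3 to compound 4 (0.11 log units; within the scatter) is estimated to remain within the scatter.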

Compound 4, half-maximal inhibitory concentration: 500 nM
The estimate for compound 4 equals the measured number at the digits printed, within the range that was stated.
By their numbers in this assay, from the lowest: compounds 4 and 3 (each within the scatter of the next); then compound 2. At a limit, above all of these: compound 1.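

At this place, on a saturated chain carbon, three bonds along the chain from a carbonyl carbon, allyl in place of vinyl gives a 1.3-fold lower number from compound 3 to compound 4 (0.11 log units; within the scatter) in this assay. Among the compounds shown here, the position therefore takes this change with no shift that can be told from the scatter, something the earlier compounds, which differ in more than one place, could not show. Nothing measured here gives a cause for this step. The compounds shown leave open how but-3-en-1-yl or a longer chain would read here, and whether a terminal amine or carboxylic acid would be tolerated in place of the alkene.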